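A few compounds are considered here, and "the series" means these few. Any claim that something is new, unique, unknown or untested is made for them only; others in the source may bear on it.

Three compounds share one core and differ only in what hangs on a nitrogen on an aromatic ring. Compound 1 `CC(O)CNc1nc(-c2ccccc2)nc2c1nnn2Cc1ccccc1Cl` carries a 1-hydroxyethyl group on the saturated chain carbon bound to that nitrogen, and in an assay on isolated protein for binding affinity to adenosine receptor A1 (Bos taurus) (on this read-out lower numbers stand for stronger inhibition and higher numbers for weaker inhibition), compound 1 gives 32000000 nM. Compound 2 `CNc1nc(-c2ccccc2)nc2c1nnn2Cc1ccccc1Cl` has hydrogen in that position; in this assay compound 2 gives 191000000 nM. Compound 3 `CCNc1nc(-c2ccccc2)nc2c1nnn2Cc1ccccc1Cl` has methyl there; in this assay compound 3 gives 463000000 nM, the highest of the three numbers, and its distance from each of the other two lies beyond the scatter. The measured steps read a 6.0-fold higher number from compound 1 to compound 2 (0.78 log units; beyond the scatter), a 14-fold higher number from compound 1 to compound 3 (1.16 log units; beyond the scatter) and a 2.4-fold higher number from compound 2 to compound 3 (0.38 log units; beyond the scatter), so every change at that chain carbon moved the number beyond the scatter, in one case by a large step.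

Compound 4 `COc1ccc(C(=O)Nc2nc(-c3ccccc3)nc3c2nnn3Cc2ccccc2Cl)cc1` is not yet measured. Its change from compound 3 is (4-methoxyphenyl)carbonyl in place of ethyl on a nitrogen on an aromatic ring. Among the measured compounds shown here, none of the measured steps touches this change: all three alter the saturated chain carbon, whereas here the entire ethyl group is exchanged for a larger group. The measured steps show only that this assay responds to what sits on this nitrogen, not in which direction. Compound 4 is therefore expected, with wide uncertainty, near 300000000 nM, between 30000000 nM and 3000000000 nM, which means an expected step of a 1.5-fold lower number from compound 3 to compound 4 (0.19 log units; within the scatter).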

Compound 4, inhibition constant: 20000000 nM
Beside the measured number, compound 4's estimate is 15-fold (1.18 log units) above it; the measured number lies below the stated range.
By their numbers in this assay, from the lowest: compounds 4 and 1 (each within the scatter of the next); then compound 2; then compound 3.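

In this assay, the step of a 23-fold lower number from compound 3 to compound 4 (1.36 log units; beyond the scatter) is the largest change yet seen at this nitrogen, and the step of a 9.6-fold lower number from compound 2 to compound 4 (0.98 log units; beyond the scatter) runs the same way. Among the compounds shown here, the earlier compounds carried only saturated chains here, so this is the first sign that a (4-methoxyphenyl)carbonyl group, with its aromatic ring and its carbonyl, can replace such a chain and still give a low number. The step of a 1.6-fold lower number from compound 1 to compound 4 (0.20 log units; within the scatter) lies within the scatter, so this large group and the 2-hydroxypropyl chain cannot be told apart, even though they have little in common beyond their attachment to the same nitrogen.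

Nothing available here explains any of these shifts. From the compounds shown here alone, it remains open whether the carbonyl, the aromatic ring or the methoxy group accounts for the change from the ethyl compound, and an acetyl group, a plain benzoyl group or a butyl chain on this nitrogen would help separate those parts.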